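This account rests on a few compounds, and the source may have more. Where it says the series, first, only, none or still open, it means among the compounds named here.

Working notes on the series. Among the compounds with values here, compound 1 `Cc1nc(S(C)(=O)=O)ccc1Oc1ncnc(OC2CCN(C(=O)OC3CCC3)CC2)c1F` stands highest of the three numbers so far: in a functional assay on isolated protein for inhibition of Glucose-dependent insulinotropic receptor (Rattus norvegicus), read by HTRF and cAMP accumulation (on this read-out lower numbers stand for an effect already at smaller amounts and higher numbers for an effect only at larger amounts of compound), compound 1 gives 167 nM. Compound 3 `Cc1nc(S(C)(=O)=O)ccc1Oc1ncnc(OC2CCN(C(=O)OC(C)(C)CF)CC2)c1F` sits nearest, with 138 nM, and a 1.2-fold lower number from compound 1 to compound 3 (0.08 log units; within the scatter). Compound 2 `Cc1nc(S(C)(=O)=O)ccc1Oc1ncnc(OC2CCN(C(=O)OC(C)(C)C(F)(F)F)CC2)c1F` is furthest, with 47.2 nM, and a 3.5-fold lower number from compound 1 to compound 2 (0.55 log units; beyond the scatter). Within the pair that shares the open chain on the oxygen, a 2.9-fold higher number from compound 2 to compound 3 (0.47 log units; beyond the scatter).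

Compound 4 `Cc1nc(S(C)(=O)=O)ccc1Oc1ncnc(OC2CCN(C(=O)O[C@H](C)C(F)(F)F)CC2)c1F` is not yet measured. Against compound 1 the difference is 1-(trifluoromethyl)ethyl in place of cyclobutyl on an oxygen next to a carbonyl group. Within the data shown here, the steps that bear on it are the two in which an open chain replaced cyclobutyl on the same oxygen: the trifluoromethyl-bearing chain of compound 2 gave a modest lowering beyond the scatter, the fluoromethyl-bearing chain of compound 3 stayed within it. Compound 4 carries trifluoromethyl but one methyl less than compound 2, so the expectation is a lowering of the same kind, possibly smaller, in this assay: for compound 4 the estimate is a 2.4-fold lower number from compound 1 to compound 4 (0.38 log units; beyond the scatter). Compound 4 is thus expected at 70 nM, within 30 nM to 160 nM, pending the measurement.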

Compound 4, half-maximal effective concentration: 110 nM
The estimate for compound 4 lay 1.6-fold (0.20 log units) below the measured number; low and high end bracket the measured number.
By their numbers in this assay, from the lowest: compound 2; then compounds 4, 3 and 1 (each within the scatter of the next).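

In this assay, trifluoromethyl alone does not carry the lowering on this oxygen: 1-(trifluoromethyl)ethyl in place of cyclobutyl gives a 1.5-fold lower number from compound 1 to compound 4 (0.18 log units; within the scatter), and the same group in place of 1-(fluoromethyl)-1-methylethyl gives a 1.3-fold lower number from compound 3 to compound 4 (0.10 log units; within the scatter). The two trifluoromethyl-bearing chains differ by one methyl, and that difference reads as a 2.3-fold higher number from compound 2 to compound 4 (0.37 log units; beyond the scatter), so among the groups shown only 1-methyl-1-(trifluoromethyl)ethyl stands clear of the others. Nothing at hand accounts for this step.

The compounds shown leave open how the opposite stereocentre of 1-(trifluoromethyl)ethyl would read. Also open, going by these compounds, is whether cyclopentyl, or tert-butyl with no fluorine at all, on this oxygen would come close to compound 2 at 47.2 nM.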